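From a Pyrimidine Amine to an Indole Amine

The source may hold more compounds than are shown below. What is called first, only, known or untested is meant among the compounds shown, and "the series" means these compounds.

Of the compounds shown here, two sharing one core have been measured in a functional assay on DU-145 cells (Homo sapiens) for inhibition, read by trypan blue exclusion, with a stated time of 72 h; on this read-out higher numbers stand for weaker inhibition and lower numbers for stronger inhibition. Compound 1 `Cn1c(=O)c(S(=O)(=O)c2ccccc2)cc2cnc(Nc3cnc4[nH]ccc4c3)nc21` gives 1000 nM in this assay. Compound 2 `Cn1c(=O)c(S(=O)(=O)c2ccc(F)cc2F)cc2cnc(Nc3ccncn3)nc21` gives 50000 nM in this assay. Of these two numbers, compound 2 stands highest; its nearest neighbour, compound 1, sits far lower, well beyond the scatter. The two differ in more than one place, so their gap cannot be tied to any single change.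

Compound 3 `Cn1c(=O)c(S(=O)(=O)c2ccc(F)cc2F)cc2cnc(Nc3ccc4cc[nH]c4c3)nc21` has not yet been measured. It differs from compound 2 in one place: 1H-indol-6-yl in place of pyrimidin-4-yl on a nitrogen on an aromatic ring. Going by the values given here, no step between measured compounds isolates this change, so its size cannot be read off directly. Among the compounds with values here, the only guidance is that compound 2 with its pyrimidin-4-yl amine gives 50000 nM, whereas compound 1, which carries a larger amine, gives 1000 nM.

On that basis a large fall in the number is expected, a 33-fold lower number from compound 2 to compound 3 (1.52 log units; beyond the scatter). Compound 3 is accordingly estimated at 1500 nM, with a range from 300 nM to 8000 nM.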

Compound 3, half-maximal inhibitory concentration: 5000 nM
Compound 3: middle estimate off by 3.3-fold (0.52 log units), on the low side, within the range that was stated.
By their numbers in this assay, from the lowest: compound 1; then compound 3; then compound 2.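

In this assay, going by these compounds alone, the change from pyrimidin-4-yl to 1H-indol-6-yl on the nitrogen gives a 10-fold lower number from compound 2 to compound 3 (1.00 log units; beyond the scatter) and is the first single change in this set whose size can be read, showing that this group alone moves the number beyond the scatter. The step still bundles several differences, since the 1H-indol-6-yl group has 9 heavy atoms against 6, 1 hydrogen-bond donor against 0, and 0 hydrogen-bond acceptors against 2, and the two compounds cannot separate these from one another. Nothing measured here bears on why the number falls.

Compound 1 differs from compound 3 in more than one place, so the gap between their values cannot be tied to the amine group or to the fluorines on the phenyl sulfonyl group. The compounds shown leave open whether a plain phenyl on the same nitrogen would give a similar step, and whether a 1-methyl-1H-indol-6-yl group, which replaces the indole hydrogen with a methyl, would keep it.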